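The source may hold more compounds than are shown below. What is called first, only, known or untested is meant among the compounds shown, and "the series" means these compounds.

Compound 1 `COc1ccc(Cl)cc1S(=O)(=O)Nc1ccc(-c2nc3ccccc3o2)cc1` was tested in an ADME assay on HEK293 cells (Homo sapiens) for cytotoxicity, read by resazurin assay, with a stated time of 48 h (on this read-out lower numbers stand for higher toxicity in this test and higher numbers for lower toxicity in this test), and gave 75000 nM. Compound 2 `CCc1ccc(S(=O)(=O)Nc2ccc3oc(-c4ccccc4)nc3c2)cc1` gave 81000 nM in this assay. Of these two numbers, compound 1 has the lower one, yet compound 2 sits so close that the two fall within the scatter of repeated measurements, so no order between them can be read. Within the data shown here, no step between measured compounds has been worked out for this set. Compound 3 `O=S(=O)(Nc1ccc(-c2nc3ccccc3o2)cc1)c1ccc(Cl)cc1` has not yet been measured in this assay. It differs from compound 1 in a single place: 4-chlorophenyl in place of 5-chloro-2-methoxyphenyl on a sulfonyl sulfur. Among the measured compounds shown here, with only two measured compounds, both of the same size, there is no basis for expecting a large move in either direction. In this assay the expected step is a 1.1-fold lower number from compound 1 to compound 3 (0.03 log units; within the scatter), which is within the scatter. Compound 3 is therefore estimated at 70000 nM in this assay, within a range from 30000 nM to 160000 nM.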

Compound 3, half-maximal cytotoxic concentration: > 100000 nM
Compound 3 ended at the assay's limit; the forecaster's own chance of this, stated with the estimate: 25%; at least 1.4-fold (0.15 log units) between middle value and limit.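

Swapping 5-chloro-2-methoxyphenyl for 4-chlorophenyl on a sulfonyl sulfur gives the first step at this place in this assay, an at least 1.3-fold higher number from compound 1 to compound 3 (0.12 log units; that floor lies within the scatter), so this change gives no sign of higher toxicity in this test. Compound 3 gives > 100000 nM, which is a limit of the assay and not a number. The step is therefore only a floor, its true size is unknown, and even that floor does not separate the two compounds beyond the scatter: the limit of > 100000 nM in this assay, at which 1 of the 3 values shown sits.

The compounds shown do not tell which part of this change carries the step, the methoxy group or the place of the chlorine. They also leave open how this assay would respond to an amine or a carboxylic acid on the ring at this sulfonyl sulfur.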